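The source may hold more compounds than are shown below. What is called first, only, known or untested is meant among the compounds shown, and "the series" means these compounds.

Working notes on the series. Compound 1 `CCCc1cc2ccccc2nc1-c1cc(-c2ccc(F)cc2)no1`, compound 2 `CCCCc1cc2ccccc2nc1-c1cc(-c2ccc(F)cc2)no1` and compound 3 `CCCCc1cc2ccccc2nc1-c1cc(-c2ccc(C)cc2)no1` have been measured; compound 4 `CCCCCc1cc2ccccc2nc1-c1cc(-c2ccc(C)cc2)no1` has not. In a functional assay on A549 cells (Homo sapiens) for inhibition, read by MTT assay, with a stated time of 24 h (on this read-out lower numbers stand for stronger inhibition and higher numbers for weaker inhibition), compound 1 gives 51300 nM and compound 2 gives 27500 nM. The change between them is methyl in place of hydrogen on a saturated chain carbon, three bonds along the chain from an aromatic carbon, and it gives a 1.9-fold lower number from compound 1 to compound 2 (0.27 log units; within the scatter). Compound 3 differs from compound 2 by methyl in place of fluoro on an aromatic carbon, a step of an at least 3.6-fold higher number from compound 2 to compound 3 (0.56 log units; beyond the scatter). For compound 3 this assay reports only a limit, > 100000 nM, at the limit of > 100000 nM in this assay, at which 1 of the 3 values shown sits. The difference between compound 1 and compound 3 is not broken down here. For the measured compounds named here, compound 4 arises from compound 3 by methyl in place of hydrogen on a saturated chain carbon, four bonds along the chain from an aromatic carbon; this is the same kind of change as the one from compound 1 to compound 2, the entering methyl sitting four bonds along the chain from an aromatic carbon instead of three. Compound 4 is expected to show a step of an at least 1.1-fold lower number from compound 3 to compound 4 (0.04 log units; that floor lies within the scatter), an expectation resting on the earlier within-scatter step a 1.9-fold lower number from compound 1 to compound 2 (0.27 log units; within the scatter) and weakened by compound 3 giving only a limit. Compound 4 is therefore estimated at 90000 nM, between 40000 nM and 250000 nM, and may again return only a limit.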

Compound 4, half-maximal inhibitory concentration: > 100000 nM
Compound 4: no number, only a limit; the forecaster's own chance of this, stated with the estimate: 50%; at least 1.1-fold (0.04 log units) between middle value and limit.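

In this assay compound 4 returns only a limit, > 100000 nM. Compound 3 stands at the same limit, so no step between compound 3 and compound 4 can be read: the limit of > 100000 nM in this assay, at which 2 of the 4 values shown sit.

The compounds shown leave open whether methyl in place of hydrogen at this chain carbon changes the read-out at all.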